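Swapping a Propyl for a Larger Group on the Amide Nitrogen

The source may report more compounds than this note shows. Statements on the series, on what has been measured and on what is new or still open speak of the compounds shown alone.

Of the compounds shown here, two of a shared core have been measured in an ADME assay on HEK293 cells (Homo sapiens) for antiproliferative activity, read by MTT assay; on this read-out lower numbers stand for stronger inhibition and higher numbers for weaker inhibition. Compound 1, with the structure `Nc1c(C(=O)N/N=C/c2ccc(Br)cc2)oc2nc(-c3cccs3)cc(C(F)(F)F)c12`, gives 86000 nM in this assay. Compound 2, with the structure `CCCNC(=O)c1oc2nc(-c3ccccc3)cc(C(F)(F)F)c2c1N`, gives 81000 nM in this assay. These two numbers lie within the scatter of each other, so compound 2 cannot be set apart from compound 1 on this read-out, and both sit at very weak inhibition.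

Compound 3, with the structure `Nc1c(C(=O)N/N=C/c2ccc(Br)cc2)oc2nc(-c3ccccc3)cc(C(F)(F)F)c12`, has not yet been measured. It differs from compound 2 in one place: a group of 9 heavy atoms (7 carbon, 1 nitrogen, 1 bromine; one six-membered aromatic ring of carbon only) in place of a group of 3 heavy atoms (3 carbon; no ring), on an amide-type nitrogen. Compound 1 already carries this same larger group, on a different core, and its value lies within the scatter of compound 2. On that ground, no step beyond the scatter is expected in this assay from compound 2 to compound 3 (a 1.0-fold higher number from compound 2 to compound 3 (0.02 log units; within the scatter)). Compound 3 is therefore estimated at 85000 nM in this assay, with a range from 40000 nM to 180000 nM.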

Compound 3, half-maximal inhibitory concentration: 64000 nM
For compound 3 the middle estimate is 1.3-fold (0.12 log units) above the measured one; the range from low to high includes it.
By their numbers in this assay, from the lowest: compounds 3, 2 and 1 (each within the scatter of the next).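

Among the compounds shown here, in (this assay), compound 3 gives the first comparison of the propyl and the larger bromine-bearing group on one shared core, and the two cannot be told apart (a 1.3-fold lower number from compound 2 to compound 3 (0.10 log units; within the scatter)). It also isolates phenyl in place of thiophen-2-yl on an aromatic carbon, a swap that the earlier pair mixed with the change on the amide-type nitrogen, and this step also lies within the scatter (a 1.3-fold lower number from compound 1 to compound 3 (0.13 log units; within the scatter)). Nothing at hand bears on why these steps are so small.

As far as these compounds go, whether any group on this nitrogen can move the number beyond the scatter remains open, since all three compounds sit at very weak inhibition. How the same group without its bromine, a longer chain, an amine or a carboxylic acid would read there is also unknown.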